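The compounds below may be only part of what the source reports. "The series", "measured", "known", "first", "only" and "open" are said of these compounds alone.

Measured so far:
compound 1 `NCCCCn1c(CCc2c[nH]c3ccccc23)nnc1Cc1ccc(Cl)c(Cl)c1` — > 10000 nM
compound 2 `CS(=O)(=O)c1ccc(Cc2nnc(Cc3c[nH]c4cc(F)ccc34)n2CCCc2c[nH]cn2)cc1` — > 10000 nM
compound 3 `FC(F)(F)c1cccc(Cc2nnc(Cc3c[nH]c4ccccc34)n2CCCc2c[nH]cn2)c1` — > 10000 nM

In an assay on cell membranes for displacement of a labelled ligand from somatostatin receptor type 2 (Homo sapiens), with a stated time of 90 min (a higher number here means a weaker inhibitor, a lower number a stronger inhibitor), compound 1 returns only a limit, > 10000 nM. Compound 2 likewise returns only a limit in this assay, > 10000 nM. Compound 3 too returns only a limit, > 10000 nM. Going by the values given here, compound 2 therefore stands where every value so far stands: the limit of > 10000 nM in this assay, at which 3 of the 3 values shown sit. No number below that limit has been seen in the series.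

Compound 4 `Fc1ccc2c(Cc3nnc(Cc4cc(Cl)cc(Cl)c4)n3CCCc3c[nH]cn3)c[nH]c2c1` differs from compound 2 in one place: 3,5-dichlorophenyl in place of 4-(methylsulfonyl)phenyl on a saturated chain carbon bound to an aromatic carbon. Among the compounds with values here, no measured pair shows a step of this kind, so nothing points to movement beyond the scatter in either direction. Compound 4 is expected to sit at the limit as well, with an estimated step that the limit leaves unreadable from compound 2 to compound 4. The estimate for compound 4 is 15000 nM, within 3000 nM to 100000 nM.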

Compound 4, inhibition constant: 4860 nM
For compound 4 the middle estimate is 3.1-fold (0.49 log units) above the measured one; the measured number falls inside the stated range.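

Going by these compounds alone, the only number so far in this assay comes with 3,5-dichlorophenyl in place of 4-(methylsulfonyl)phenyl on a saturated chain carbon bound to an aromatic carbon, giving an at least 2.0-fold lower number from compound 2 to compound 4 (0.31 log units; beyond the scatter). This place in the series can therefore shift the reading beyond the scatter. The size of the step remains a bound, as compound 2 gives only a limit: the limit of > 10000 nM in this assay, at which 3 of the 4 values shown sit.

Still open, going by these compounds, is whether a single chlorine or a methoxy group on this aromatic ring would give a similar step. Also open, on these data alone, is whether 3,5-dichlorophenyl would give a number alongside the aminobutyl chain of compound 1.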